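The compounds below may be only part of what the source reports. "The series", "measured", "known", "first", "only" and "open" are said of these compounds alone.

Compound 1 `CCOc1ccc(N/N=C2\CCC(C)n3c2ncc(C(=O)O)c3=O)cc1`: 17600 nM
Compound 2 `CC(=O)c1ccc(N/N=C2\CCC(C)n3c2ncc(C(=O)O)c3=O)cc1`: 8100 nM

In a functional assay (mast cells) for inhibition, with Rattus norvegicus as the target (a lower number here means that less compound is needed, a higher number that more compound is needed for the effect), compound 2 holds the lower of the two numbers, at 8100 nM. Compound 3 `CC1CC/C(=N\Nc2ccc(C3CC3)cc2)c2ncc(C(=O)O)c(=O)n21` has cyclopropyl in place of acetyl on an aromatic carbon, para to a large group (cyclopropyl in place of acetyl on an aromatic carbon). Among the measured compounds shown here, only one measured step bears on this change: a 2.2-fold lower number from compound 1 to compound 2 (0.34 log units; beyond the scatter), which was modest. For the measured compounds named here, that step involved acetyl, but no measured compound carries cyclopropyl. A step no larger than that one is therefore expected, leaning towards a higher number. The estimated step is a 1.5-fold higher number from compound 2 to compound 3 (0.17 log units; within the scatter). Compound 3 is expected at about 12000 nM, within an estimated range of 5000 nM to 28000 nM.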

Compound 3, half-maximal effective concentration: 1000 nM
The estimate for compound 3 lay 12-fold (1.08 log units) above the measured number, outside the stated range (below it).
By their numbers in this assay, from the lowest: compound 3; then compound 2; then compound 1.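

In this assay, the aromatic carbon para to a large group proves far more responsive than the earlier pair suggested: cyclopropyl in place of acetyl, with the same count of 3 heavy atoms, gives an 8.1-fold lower number from compound 2 to compound 3 (0.91 log units; beyond the scatter). Against ethoxy, the same group gives an 18-fold lower number from compound 1 to compound 3 (1.25 log units; beyond the scatter), leaving compound 3 with the lowest number of the three. No available evidence accounts for this change. The compounds shown leave open whether the three-membered ring itself matters, since isopropyl would test that directly. They also leave open how cyclobutyl or an amine would behave at this position.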